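Alkynyl extension on the core of compound 1

This account rests on a few compounds, and the source may have more. Where it says the series, first, only, none or still open, it means among the compounds named here.

Compound 1 `O=c1nc2oc(CCCCl)cc2cn1Cc1cn(-c2ccc(F)cc2)nn1` is the compound with the lowest number among those measured. In an ADME assay on WI-38 cells (Homo sapiens) for antiproliferative activity, read by MTT assay, with a stated time of 72 h (on this read-out higher numbers stand for weaker inhibition and lower numbers for stronger inhibition), compound 1 gives < 10 nM, which is a limit of the assay rather than a number (the limit of < 10 nM in this assay, at which 1 of the 3 values shown sits). Compound 2 `O=c1nc2oc(CCCCl)cc2cn1Cc1cn(Cc2ccccc2)nn1` gives 5200 nM in this assay. Compound 3 `O=c1nc2oc(CCCCl)cc2cn1Cc1cn(-c2ccc(Cl)cc2)nn1` gives 72500 nM in this assay. The three measured steps all change the group on the aromatic nitrogen: an at least 520-fold higher number from compound 1 to compound 2 (2.71 log units; beyond the scatter), an at least 7200-fold higher number from compound 1 to compound 3 (3.86 log units; beyond the scatter) and a 14-fold higher number from compound 2 to compound 3 (1.14 log units; beyond the scatter).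

Compound 4 `O=c1nc2oc(CCCCl)c(C#CCCCCCl)c2cn1Cc1cn(-c2ccc(F)cc2)nn1` differs from compound 1 by 6-chlorohex-1-yn-1-yl in place of hydrogen on an aromatic carbon, the new group sitting on an aromatic carbon of the five-membered aromatic ring with one oxygen, next to the ring atom that bears a 3-chloropropyl group. For the measured compounds named here, none of the measured steps touches that ring; all of them alter the substituent on the aromatic nitrogen and so give no direct reading on this change. From the compounds shown here alone, with nothing pointing to a shift, no step beyond the scatter is expected in this assay, but the estimate is loose, since compound 1 sits at a limit and its true number is unknown. Compound 4 is expected to give 10 nM, in the range 2 nM to 80 nM. The expected step is a number no lower from compound 1 to compound 4 (the limit leaves the size open).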

Compound 4, half-maximal inhibitory concentration: 70 nM
Compound 4: middle estimate off by 7.0-fold (0.85 log units), on the low side; measured number inside the range.
By their numbers in this assay, from the lowest: compound 4; then compound 2; then compound 3. At a limit, below all of these: compound 1.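

For the compounds shown here, the earlier compounds varied only the group on the aromatic nitrogen, whereas compound 4 gives a first reading on the five-membered aromatic ring with 1 oxygen: in this assay, 6-chlorohex-1-yn-1-yl in place of hydrogen gives an at least 7.0-fold higher number from compound 1 to compound 4 (0.84 log units; beyond the scatter). With the 4-fluorophenyl group kept, compound 4 gives 70 nM, a true number rather than a limit, so this substitution pattern on the aromatic nitrogen now has a measured reference point. Compound 1 is held only by a limit of the assay, so the true size of the step stays open: the limit of < 10 nM in this assay, at which 1 of the 4 values shown sits.

Open, from the compounds shown here alone, is which part of the 6-chlorohex-1-yn-1-yl group carries the step: the terminal chlorine, the triple bond or the chain length. A hexynyl chain without chlorine, a saturated hexyl chain or a shorter alkynyl chain ending in an amine at this position would tell these apart, and whether the step holds with benzyl on the aromatic nitrogen is equally unsettled.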